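The source may report more compounds than this note shows. Statements on the series, on what has been measured and on what is new or still open speak of the compounds shown alone.

Of the compounds shown here, three sharing one core have been tested in a functional assay on the whole organism for inhibition, with Rattus norvegicus as the target; a higher number here means that more compound is needed for the effect, a lower number that less compound is needed. Compound 1 `CC1CC/C(=N\Nc2ccccc2Br)c2ncc(C(=O)O)c(=O)n21` reaches only a limit in this assay, giving > 320 umol/kg. Compound 2 `CC1CC/C(=N\Nc2ccc(I)cc2)c2ncc(C(=O)O)c(=O)n21` also stops at a limit in this assay, giving > 1000 umol/kg. Compound 3 `COc1ccccc1N/N=C1\CCC(C)n2c1ncc(C(=O)O)c2=O` likewise gives a limit in this assay, namely > 1000 umol/kg. Because of the limit of > 1000 umol/kg in this assay, at which 2 of the 3 values shown sit, and (the limit of > 320 umol/kg in this assay, at which 1 of the 3 values shown sits), none of these three results is a true number, so compound 2 stands only at a limit, as do compound 1 and compound 3. The steps among them cannot be read either: a step that the two limits leave unreadable from compound 1 to compound 2, a step that the two limits leave unreadable from compound 1 to compound 3 and a step that the two limits leave unreadable from compound 2 to compound 3. Compound 4 `CCOc1ccc(N/N=C2\CCC(C)n3c2ncc(C(=O)O)c3=O)cc1` differs from compound 2 in one place: ethoxy in place of iodo on an aromatic carbon. Among the measured compounds shown here, no measured step tells what size of change such a swap brings in this assay, so no direction can be expected beyond the scatter. The step from compound 2 to compound 4 is estimated as a step that the limit leaves unreadable from compound 2 to compound 4. Compound 4 is therefore expected to give about 1500 umol/kg in this assay, within a range from 300 umol/kg to 6000 umol/kg, most probably once more only as a limit.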

Compound 4, dose for 50% inhibition: > 100 umol/kg
Compound 4 gave a limit, no number; the forecaster's own chance of this, stated with the estimate: 75%; the middle value is on the limit's open side.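

In this assay compound 4 gives > 100 umol/kg, which is a limit and not a number. Compound 2 also has only a limit, so the step between compound 2 and compound 4 cannot be read. The compounds shown leave open what dose any of them needs for the effect, and whether ethoxy in place of iodo changes that dose.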